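Replacing the (4-methoxyphenoxy)methyl group on the carbonyl carbon

The source may report more compounds than this note shows. Statements on the series, on what has been measured and on what is new or still open speak of the compounds shown alone.

For the measured compounds named here, compound 1 `COc1ccc(OCC(=O)N2CCN(c3ccc(C(F)(F)F)cc3[C@@H](N)CC(C)C)CC2)cc1` gives 3800 nM in an assay on HEK293 cells for displacement of a labelled ligand from Melanocortin receptor 4 (Homo sapiens) (on this read-out higher numbers stand for weaker inhibition and lower numbers for stronger inhibition), and stands as the highest of the three numbers so far. Compound 2 `CC(C)C[C@H](N)c1cc(C(F)(F)F)ccc1N1CCN(C(=O)[C@H](C)Cc2ccc(Cl)cc2)CC1` gives 31 nM in this assay, and compound 3 `CC(C)C[C@H](N)c1cc(C(F)(F)F)ccc1N1CCN(C(=O)C(C)Cc2ccc(Cl)cc2O)CC1` gives 36 nM in this assay. Both carry a branched group on the carbonyl carbon in place of the (4-methoxyphenoxy)methyl of compound 1, and both steps are large: a 120-fold lower number from compound 1 to compound 2 (2.09 log units; beyond the scatter) and a 110-fold lower number from compound 1 to compound 3 (2.02 log units; beyond the scatter). The extra hydroxy group makes no difference that can be resolved, a 1.2-fold higher number from compound 2 to compound 3 (0.06 log units; within the scatter).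

Compound 4 `CCOc1cccc(CC(C)C(=O)N2CCN(c3ccc(C(F)(F)F)cc3[C@@H](N)CC(C)C)CC2)c1` is not yet measured. It differs from compound 1 as follows: 1-(3-ethoxybenzyl)ethyl in place of (4-methoxyphenoxy)methyl on a carbonyl carbon. Going by the values given here, this is the same kind of exchange as in the two measured steps, although the substitution pattern on the aromatic ring differs from both; no measured pair tells how that matters. A large decrease in the inhibition constant is therefore expected, a 48-fold lower number from compound 1 to compound 4 (1.68 log units; beyond the scatter), perhaps somewhat smaller than for compound 2 because of a 120-fold lower number from compound 1 to compound 2 (2.09 log units; beyond the scatter) resting on a different ring substituent. The estimate for compound 4 in this assay is 80 nM, within 20 nM to 400 nM.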

Compound 4, inhibition constant: 2200 nM
Compound 4: middle estimate off by 28-fold (1.44 log units), on the low side, outside the stated range (above it).
By their numbers in this assay, from the lowest: compounds 2 and 3 (each within the scatter of the next); then compounds 4 and 1 (each within the scatter of the next).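

A branched chain on the carbonyl carbon does not bring the gain by itself: in this assay the 1-(3-ethoxybenzyl)ethyl group gives a 1.7-fold lower number from compound 1 to compound 4 (0.24 log units; within the scatter) and the two compounds cannot be told apart. The aromatic ring on that chain now carries the difference, with a 61-fold higher number from compound 3 to compound 4 (1.79 log units; beyond the scatter) and a 71-fold higher number from compound 2 to compound 4 (1.85 log units; beyond the scatter) when 3-ethoxyphenyl replaces the chlorine-bearing rings. Nothing at hand accounts for this split.

For the compounds shown here, it remains open whether the ethoxy group itself or its place on the ring separates compound 4 from compound 2, since no compound here varies one without the other. A ring bearing a methyl, nitrile or amine group in place of ethoxy would show how narrow the requirement at this position is.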